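Oxan-4-yl in Place of a Piperidine on the Sulfonyl Sulfur

The source may hold more compounds than are shown below. What is called first, only, known or untested is meant among the compounds shown, and "the series" means these compounds.

Compound 2 `CC1(C)CCN(S(=O)(=O)c2ccc(NC(=O)c3ccc([N+](=O)[O-])o3)cc2)CC1` gives 600 nM in an assay on CHO-K1 cells for activation of DNA damage-inducible transcript 3 protein (Homo sapiens), read by a luciferase reporter (a higher number here means that more compound is needed for the effect, a lower number that less compound is needed), the lowest of the two numbers shown, while compound 1 `O=C(Nc1ccc(S(=O)(=O)N2CCC(Cl)CC2)cc1)c1ccc([N+](=O)[O-])o1` gives 800 nM, within the scatter of compound 2. Compound 3 `O=C(Nc1ccc(S(=O)(=O)C2CCOCC2)cc1)c1ccc([N+](=O)[O-])o1` differs from compound 2 by oxan-4-yl in place of 4,4-dimethylpiperidin-1-yl on a sulfonyl sulfur. The only step that touches this place, a 1.3-fold lower number from compound 1 to compound 2 (0.12 log units; within the scatter), stayed within the scatter, and nothing shown points in either direction for the new group. The expected step is therefore a 1.2-fold higher number from compound 2 to compound 3 (0.07 log units; within the scatter), not beyond the scatter. Compound 3 is estimated at 700 nM, with a range from 250 nM to 2000 nM.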

Compound 3, concentration for half-maximal activity: 1200 nM
Estimate against measurement, compound 3: 1.7-fold (0.23 log units) below; the range from low to high includes it.
By their numbers in this assay, from the lowest: compounds 2, 1 and 3 (each within the scatter of the next).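

On the sulfonyl sulfur, oxan-4-yl stands in for either piperidine without leaving the scatter in this assay, with a 2.0-fold higher number from compound 2 to compound 3 (0.30 log units; within the scatter) and a 1.5-fold higher number from compound 1 to compound 3 (0.18 log units; within the scatter). Within the data shown here, all three six-membered non-aromatic rings at this place, including the one group that counts a hydrogen-bond acceptor, therefore give numbers within the scatter of each other. No evidence is available to explain this result. Still open, on these data alone, is whether an open chain such as n-butyl, or a ring carrying an amine or a carboxylic acid, would produce a step beyond the scatter here.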